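Title: A Carboxypyridinyl Swap and Its Expected Solubility

This account rests on a few compounds, and the source may have more. Where it says the series, first, only, none or still open, it means among the compounds named here.

Going by the values given here, compound 1, `COc1cccnc1Nc1cc2[nH]c(-c3cccc(C(F)(F)F)c3)nc2cn1`, is the only member of this small set with a measured number in a physicochemical assay for solubility, using the shake flask method, measured as kinetic solubility, with a stated time of 20 h, at pH 2; a lower number here means a less soluble compound, a higher number a more soluble compound: compound 1 gives 116000 nM. Compound 2, `Fc1cnc(Nc2cc3[nH]c(-c4cccc(C(F)(F)F)c4)nc3cn2)c(F)c1`, reaches only a limit of the assay, and in this assay compound 2 is recorded as < 5000 nM. The change that separates them, 3,5-difluoropyridin-2-yl in place of 3-methoxypyridin-2-yl on a nitrogen on an aromatic ring, produced an at least 23-fold lower number from compound 1 to compound 2 (1.36 log units; beyond the scatter), so that compound 2 sits at the limit of < 5000 nM in this assay, at which 1 of the 2 values shown sits.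

Compound 3, `O=C(O)c1ccnc(Nc2cc3[nH]c(-c4cccc(C(F)(F)F)c4)nc3cn2)c1`, differs from compound 1 in the following way: 4-carboxypyridin-2-yl in place of 3-methoxypyridin-2-yl on a nitrogen on an aromatic ring. Among the compounds with values here, the only measured step touches the same position but introduces a different group, so it bears on compound 3 only loosely; it shows that replacing the 3-methoxypyridin-2-yl group can move solubility by a large amount and downward. The author therefore expects compound 3 to show a moderately lower number than compound 1, a step of a 2.9-fold lower number from compound 1 to compound 3 (0.46 log units; beyond the scatter), with considerable uncertainty. For compound 3 the estimate in this assay is 40000 nM, with a range from 8000 nM to 150000 nM.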

Compound 3, solubility: < 5000 nM
Compound 3: a limit, no number (the forecaster's own chance of this, stated with the estimate: 25%); at least 8.0-fold (0.90 log units) between middle value and limit.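

At this place, on a nitrogen on an aromatic ring, a second replacement of 3-methoxypyridin-2-yl gives an at least 23-fold lower number from compound 1 to compound 3 (1.36 log units; beyond the scatter) in this assay, so the large step no longer belongs to 3,5-difluoropyridin-2-yl alone. Compound 3 gives < 5000 nM, which is a limit of the assay and not a number. The step between compound 2 and compound 3 cannot be read, and two quite different groups, 4-carboxypyridin-2-yl and 3,5-difluoropyridin-2-yl, now end at the same mark: the limit of < 5000 nM in this assay, at which 2 of the 3 values shown sit.

What the compounds shown leave open is how far the true values of compound 2 and compound 3 lie from that limit, and so whether these two replacements differ from each other at all. It also remains open whether the high number of compound 1 depends on the methoxy group itself, since neither a longer ether chain in its place nor an amine on the pyridine ring appears among these compounds.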